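A few compounds are considered here, and "the series" means these few. Any claim that something is new, unique, unknown or untested is made for them only; others in the source may bear on it.

Three dichloroacetamides of substituted anilines have been measured so far. Compound 1 `O=C(Nc1cccc(I)c1)C(Cl)Cl` carries an iodo group on the aromatic ring, compound 3 `Cc1ccc(NC(=O)C(Cl)Cl)cc1` a methyl group, and compound 2 `O=C(Nc1cccc(NC(=O)C(Cl)Cl)c1)C(Cl)Cl` bears two dichloroacetamide groups on one ring. In a functional assay on A549 cells (Homo sapiens) for antiproliferative activity, read by MTT assay, with a stated time of 72 h (a lower number here means a stronger inhibitor, a higher number a weaker inhibitor), compound 2 gives "not determined" (no result reported), so no number stands for it. In this assay compound 1 gives 4760 nM, while compound 3 gives 48900 nM. Compound 3 therefore stands with the higher of the two numbers, and its distance from compound 1 lies beyond the usual scatter.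

Compound 4 `O=C(Nc1ccc(Br)cc1)C(Cl)Cl` is the next structure, reached from compound 3 by a single change: bromo in place of methyl on an aromatic carbon. Among the measured compounds shown here, no step between two measured compounds matches this exchange, so the expectation leans only on the compounds above. For the measured compounds named here, since compound 1, the one halogen-bearing compound, gives 4760 nM and so sits well below compound 3, a downward step is expected, and it is estimated as a 4.1-fold lower number from compound 3 to compound 4 (0.61 log units; beyond the scatter) in this assay. Compound 4 is accordingly expected to give 12000 nM, with a range from 4000 nM to 40000 nM.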

Compound 4, half-maximal inhibitory concentration: 13700 nM
Compound 4: middle estimate off by 1.1-fold (0.06 log units), on the low side, and the stated range covers the measured number.
By their numbers in this assay, from the lowest: compound 1; then compound 4; then compound 3.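

Replacing methyl with bromo on the aromatic carbon para to a group of 6 heavy atoms gives, in this assay, a 3.6-fold lower number from compound 3 to compound 4 (0.55 log units; beyond the scatter). Among the compounds shown here, this is the first pair here that differs in one place only, so it gives the first direct reading of what a change at this position does to the number. Methyl and bromo each count as 1 heavy atom, with no ring, no hydrogen-bond donors or acceptors and no net charge, yet the step still lies beyond the scatter, and nothing measured here explains it.

Still open, as far as these compounds go, is how other groups at this same position, such as a methoxy group, an amine or a carboxylic acid, would compare with methyl and bromo. From the compounds shown here alone, it also remains unknown whether this exchange would give a similar step on another core.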